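Amide Nitrogen Swap in a Series at the Assay Limit

The source may hold more compounds than are shown below. What is called first, only, known or untested is meant among the compounds shown, and "the series" means these compounds.

Compound 1, `C=CC1=C(C(=O)Nc2ccccc2OC)C(c2ccc(OC)cc2)OC1`, in a functional assay on A549 cells (Homo sapiens) for cytotoxicity, read by MTT assay, with a stated time of 24 h (on this read-out higher numbers stand for weaker inhibition and lower numbers for stronger inhibition), gives > 100000 nM, which is a limit of the assay.
Compound 2, `C=CC1=C(C(=O)Nc2ccc(C)cc2)C(c2ccc(OC)cc2)OC1`, in this assay gives > 100000 nM, also a limit.
Compound 3, `C=CC1=C(C(=O)NCC(C)C)C(c2ccc(OC)cc2)OC1`, in this assay gives > 100000 nM, again a limit.

All three measured compounds share one core and differ only in the group on the amide-type nitrogen. Compound 3 stands where the other two stand: at the limit, as the limit of > 100000 nM in this assay, at which 3 of the 3 values shown sit, records, so none of the three can be ranked against the others.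

Compound 4, `C=CC1=C(C(=O)Nc2ccccc2)C(c2ccc(OC)cc2)OC1`, differs from compound 3 by phenyl in place of isobutyl on an amide-type nitrogen.

Among the measured compounds shown here, the steps that bear on this change are those in which isobutyl is exchanged for an aryl group on the same nitrogen: a step that the two limits leave unreadable from compound 1 to compound 3 and a step that the two limits leave unreadable from compound 2 to compound 3. Both are unreadable, since the two values on each side are limits. The step that the two limits leave unreadable from compound 1 to compound 2, from one aryl group to another, is likewise unreadable. Nothing in these data therefore shows any aryl-for-isobutyl exchange moving a value away from the limit, and a phenyl group on the nitrogen is a smaller change than the substituted aryl groups already tried.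

Compound 4 is therefore expected to stay at the limit, with an estimated step that the limit leaves unreadable from compound 3 to compound 4 from compound 3. The estimate for compound 4 in this assay is 150000 nM, within 50000 nM to 500000 nM.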

Compound 4, half-maximal inhibitory concentration: > 100000 nM
Compound 4: no number, only a limit (the forecaster's own chance of this, stated with the estimate: 85%); the middle value is on the limit's open side.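

Compound 4 sits at the same limit as compound 1, compound 2 and compound 3, so no step among these compounds can be read and none can be ranked against another: the limit of > 100000 nM in this assay, at which 4 of the 4 values shown sit.

From the compounds shown here alone, how strongly any of the four acts in this assay stays open, as does whether another group on the amide-type nitrogen would give a measurable value.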